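This account rests on a few compounds, and the source may have more. Where it says the series, first, only, none or still open, it means among the compounds named here.

In a functional assay on NCI/ADR cells (Homo sapiens) for inhibition, read by sulforhodamine B assay, with a stated time of 48 h (a lower number here means a stronger inhibitor of growth, a higher number a weaker inhibitor of growth), compound 1 `COc1ccc(/C=C/C2CC=CC(=O)O2)cc1` gives 17.3 uM. Compound 2 `COc1ccc(/C=C/C2CC=CC(=O)O2)cc1OC` gives 11.6 uM in this assay and stands at the low end of the two numbers, but the step of a 1.5-fold lower number from compound 1 to compound 2 (0.17 log units; within the scatter) is within the scatter. Compound 3 `COc1cc(/C=C/C2CC=CC(=O)O2)cc(OC)c1OC` differs from compound 2 by methoxy in place of hydrogen on an aromatic carbon. Among the measured compounds shown here, the only step of the same kind is a 1.5-fold lower number from compound 1 to compound 2 (0.17 log units; within the scatter), too small to mark a direction, so no movement beyond the scatter is expected. Compound 3 is therefore estimated at 9.5 uM, with a range from 4 uM to 24 uM, the expected step being a 1.2-fold lower number from compound 2 to compound 3 (0.09 log units; within the scatter).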

Compound 3, concentration for growth inhibition (reported as GI): 35.1 uM
Estimate against measurement, compound 3: 3.7-fold (0.57 log units) below; measured number outside the range, above it.
By their numbers in this assay, from the lowest: compounds 2 and 1 (each within the scatter of the next); then compound 3.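

Methoxy in place of hydrogen on an aromatic carbon, ortho to a methoxy group, gives a 3.0-fold higher number from compound 2 to compound 3 (0.48 log units; beyond the scatter), a weaker inhibitor of growth. The earlier step of the same kind, a 1.5-fold lower number from compound 1 to compound 2 (0.17 log units; within the scatter), showed no such movement, so across these two steps this exchange does not act alike at each place. Nothing available bears on the reason for this difference.

On these data alone, it remains open whether the weakening belongs to methoxy or to any group at this place. A hydroxyl or an amine there would separate the two.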